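The source may report more compounds than this note shows. Statements on the series, on what has been measured and on what is new or still open speak of the compounds shown alone.

Three compounds built on one shared core have numbers in an ADME assay on HEp-2 cells (Homo sapiens) for cytotoxicity; a lower number here means that less compound is tolerated, a higher number that more compound is tolerated. Compound 1 `CC(C)CCn1c(Cn2c(=O)n(C(C)C)c3ccccc32)nc2cc(CN)ccc21` gives 3920 nM, compound 2 `CNCc1ccc2c(c1)nc(Cn1c(=O)n(C(C)C)c3ccccc31)n2CCC(C)C` gives 1480 nM, and compound 3 `CC(C)CCn1c(Cn2c(=O)n(C(C)C)c3ccccc32)nc2cc(CF)ccc21` gives 37300 nM, the highest of the three. Compound 4 `CC(C)CCn1c(Cn2c(=O)n(C(C)C)c3ccccc32)nc2cc(-c3ncon3)ccc21` has yet to be measured. It differs from compound 3 as follows: 1,2,4-oxadiazol-3-yl in place of fluoromethyl on an aromatic carbon. In words, 1,2,4-oxadiazol-3-yl stands in place of fluoromethyl on an aromatic carbon.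

Within the data shown here, no measured step makes this exact swap, so the evidence is indirect. The closest guides are two steps that replace a nitrogen group with fluoro on the saturated chain carbon: a modest one, a 9.5-fold higher number from compound 1 to compound 3 (0.98 log units; beyond the scatter), and a large one, a 25-fold higher number from compound 2 to compound 3 (1.40 log units; beyond the scatter). A smaller edit, a 2.6-fold lower number from compound 1 to compound 2 (0.42 log units; beyond the scatter), shows that the number responds even to a methyl on the amine nitrogen. Compound 4, like compound 3, has no amine, and the entering group has no net charge, as does the fluoromethyl it replaces. The number of compound 4 is therefore expected to stay close to that of compound 3 at 37300 nM rather than fall towards the amines. The expected change is small, with no clear direction beyond the scatter: a 1.3-fold lower number from compound 3 to compound 4 (0.12 log units; within the scatter). From the compounds shown here alone, this ring is untested, so the range is kept wide. The estimate for compound 4 is 28000 nM, within an expected range of 9000 nM to 85000 nM.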

Compound 4, half-maximal cytotoxic concentration: 223000 nM
Estimate against measurement, compound 4: 8.0-fold (0.90 log units) below; measured number outside the range, above it.
By their numbers in this assay, from the lowest: compound 2; then compound 1; then compound 3; then compound 4.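

In this assay this aromatic carbon can carry a group that lifts the number well beyond that of the fluoromethyl compound (a 6.0-fold higher number from compound 3 to compound 4 (0.78 log units; beyond the scatter)), so compound 3 did not mark the top of the range among the compounds without an amine. Neither fluoromethyl nor 1,2,4-oxadiazol-3-yl has a net charge, so this step shows the number also moving between two uncharged groups, one an open two-atom group and the other a five-membered aromatic ring with 3 hetero atoms and 3 hydrogen-bond acceptors. Against the two amines the gaps are now the widest in the set (a 150-fold higher number from compound 2 to compound 4 (2.18 log units; beyond the scatter)) and (a 57-fold higher number from compound 1 to compound 4 (1.76 log units; beyond the scatter)), and no measurement shown here bears on what lies behind these steps.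

The compounds shown leave open whether the higher number belongs to this particular ring or would also come with another group on the same carbon, such as a nitrile, a carboxylic acid or a phenyl ring. They also leave open whether a 1,2,4-oxadiazole joined through a different ring atom, or carrying a methyl group, would give a similar number.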